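The source may hold more compounds than are shown below. What is called first, only, known or untested is meant among the compounds shown, and "the series" means these compounds.

In an ADME assay on microsomes from liver (Homo sapiens) for pharmacokinetics, read by LC-MS, with a stated time of 60 min, tested at 1 uM (a lower number here means slower removal, a higher number faster removal of the compound), compound 3 `O=C(NCc1ccc(S(=O)(=O)C2CCOCC2)cc1)N1Cc2ccncc2C1` gives 6 mL/min/kg, the lowest of the three numbers, against 14 mL/min/kg for compound 1 `O=C(NCc1ccc(S(=O)(=O)c2cccc(C(F)(F)F)c2)cc1)N1Cc2ccncc2C1` and 16 mL/min/kg for compound 2 `O=C(NCc1ccc(S(=O)(=O)C2CCCCC2)cc1)N1Cc2ccncc2C1`. Compound 4 `CC(=O)N1CCC(S(=O)(=O)c2ccc(CNC(=O)N3Cc4ccncc4C3)cc2)CC1` differs from compound 3 only on the sulfonyl sulfur: 1-acetylpiperidin-4-yl in place of oxan-4-yl on a sulfonyl sulfur. The measured steps at this place are a 2.3-fold lower number from compound 1 to compound 3 (0.37 log units; beyond the scatter) and a 2.7-fold lower number from compound 2 to compound 3 (0.43 log units; beyond the scatter), both modest, while a 1.1-fold higher number from compound 1 to compound 2 (0.06 log units; within the scatter) stayed within the scatter. None of these steps tests an acetylated ring, and the entering group keeps a six-membered non-aromatic ring with 1 hetero atom. No step beyond the scatter is therefore expected in this assay, with an estimated 1.3-fold higher number from compound 3 to compound 4 (0.12 log units; within the scatter). The estimate for compound 4 is 8 mL/min/kg, within an expected range of 4 mL/min/kg to 15 mL/min/kg.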

Compound 4, clearance: 6 mL/min/kg
The estimate for compound 4 lay 1.3-fold (0.12 log units) above the measured number; the range from low to high includes it.
By their numbers in this assay, from the lowest: compounds 3 and 4 (each within the scatter of the next); then compounds 1 and 2 (each within the scatter of the next).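

In this assay, the sulfonyl sulfur accepts 1-acetylpiperidin-4-yl in place of oxan-4-yl with no change at the digits printed from compound 3 to compound 4 (within the scatter), so the low number is not confined to oxan-4-yl. The new group also stands apart from the other two groups, with a 2.7-fold lower number from compound 2 to compound 4 (0.43 log units; beyond the scatter) and a 2.3-fold lower number from compound 1 to compound 4 (0.37 log units; beyond the scatter), which places both six-membered non-aromatic rings with a hetero atom below cyclohexyl and 3-(trifluoromethyl)phenyl. Nothing available explains these differences. From the compounds shown here alone, whether a free secondary amine on the ring, a carboxylic acid or a longer chain at this place would keep the number this low remains open.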